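Thiosemicarbazide amidines: removal of the ring methyl

A few compounds are considered here, and "the series" means these few. Any claim that something is new, unique, unknown or untested is made for them only; others in the source may bear on it.

Measured so far:
compound 1, `N/C(=N\NC(=S)N1CCOCC1)c1ccccn1`: 56.3%
compound 2, `Cc1ccnc(/C(N)=N/NC(=S)N2CCSCC2)c1`: 39.2%

In a functional assay on HeLa cells (Homo sapiens) for cytotoxicity, read by MTT assay, with a stated time of 72 h, tested at 10 uM (on this read-out higher numbers stand for more inhibition of growth at the one concentration tested and lower numbers for less inhibition of growth), compound 1 gives 56.3%, and compound 2 gives 39.2%, which is the lower of the two numbers and lies beyond the scatter from compound 1.

Compound 3, `N/C(=N\NC(=S)N1CCSCC1)c1ccccn1`, is not yet measured. It differs from compound 2 by hydrogen in place of methyl on an aromatic carbon. Among the measured compounds shown here, no step between measured compounds corresponds to this change, so no size can be computed for it; compound 1 and compound 3 share the hydrogen at this position, but differ elsewhere, and only their values themselves can be compared once compound 3 is known.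

The expectation for compound 3 rests on compound 2 giving 39.2% and compound 1 giving 56.3%: a small rise toward compound 1 is estimated, close to the scatter. Compound 3 is expected to give 47%, between 30% and 64%, an estimated step of a number 7.8 percentage points higher from compound 2 to compound 3 (within the scatter).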

Compound 3, percent growth inhibition at one concentration: 54.5%
The estimate for compound 3 lay 7.5 percentage points below the measured number; measured number inside the range.
By their numbers in this assay, from the lowest: compound 2; then compounds 3 and 1 (each within the scatter of the next).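

Putting hydrogen in place of methyl on the aromatic carbon opposite the ring nitrogen gives a number 15.3 percentage points higher from compound 2 to compound 3 (beyond the scatter) in this assay, so this position responds to the change, at least in this single pair. Thiomorpholin-4-yl in place of morpholin-4-yl on the thiocarbonyl carbon gives a number 1.8 percentage points lower from compound 1 to compound 3 (within the scatter), so the earlier gap between compound 1 and compound 2 follows the methyl and not the exchange of these two rings. Nothing available explains why the methyl matters here.

The compounds shown leave open whether an ethyl, a methoxy or a chlorine on this aromatic carbon would read like compound 2 or like compound 3. Also open, on these data alone, are whether the methyl step carries over to the morpholin-4-yl compounds and whether a piperazine on the thiocarbonyl carbon would match compound 3.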